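Swapping the amide aryl group on a thiazole core

The source may hold more compounds than are shown below. What is called first, only, known or untested is meant among the compounds shown, and "the series" means these compounds.

Compound 1 `CCOC(=O)c1sc(-c2cccc(NC(=O)c3ccc(F)cc3)c2)nc1Nc1ccc(N2CCN(C)CC2)cc1` carries a 4-fluorophenyl group on the amide carbonyl. Going by the values given here, in a functional assay on Raji cells (Homo sapiens) for antiproliferative activity, read by CCK-8 assay, with a stated time of 72 h, tested at 40 uM (on this read-out lower numbers stand for less inhibition and higher numbers for more inhibition at the one concentration tested (going by the name of the read-out)), compound 1 gives 16.8%, the highest of the two numbers measured so far. Among the compounds with values here, its only measured neighbour is compound 2 `CCOC(=O)c1sc(-c2cccc(NC(=O)c3ccc(C(C)(C)C)cc3)c2)nc1Nc1ccc(N2CCN(C)CC2)cc1`, which in this assay gives 4.22%; the step of a number 12.6 percentage points lower from compound 1 to compound 2 (beyond the scatter) shows that changing the group on that aromatic ring lowered inhibition by a modest amount.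

Compound 3 `CCOC(=O)c1sc(-c2cccc(NC(=O)c3ccc(C(F)(F)F)cn3)c2)nc1Nc1ccc(N2CCN(C)CC2)cc1` changes the same part of the molecule in a different way: 5-(trifluoromethyl)pyridin-2-yl in place of 4-fluorophenyl on a carbonyl carbon. Within the data shown here, no measured step covers this exact replacement. Among the measured compounds shown here, the step from compound 1 to compound 2 is the only guide, and it shows that altering this aryl group can shift inhibition by roughly a dozen points, in the downward direction. Since the new group is unlike tert-butyl, the direction for compound 3 is uncertain, and the step of a number 4.8 percentage points lower from compound 1 to compound 3 (within the scatter) is expected to stay small, possibly within the scatter. Compound 3 is therefore estimated at 12%, with a range from 0% to 30%.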

Compound 3, a percentage reported as inhibition, at one concentration (the size of the read-out at that concentration, not a potency): 20.8%
The estimate for compound 3 lay 8.8 percentage points below the measured number; measured number inside the range.
By their numbers in this assay, from the lowest: compound 2; then compounds 1 and 3 (each within the scatter of the next).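

In this assay the switch to 5-(trifluoromethyl)pyridin-2-yl on the carbonyl carbon gives a number 4 percentage points higher from compound 1 to compound 3 (within the scatter) even though the new group has more heavy atoms than 4-fluorophenyl and brings a ring nitrogen, so a quite different aryl group can sit here and the read-out stays level with that of compound 1. Set against the tert-butyl compound, the same group gives a number 16.6 percentage points higher from compound 2 to compound 3 (beyond the scatter) and this shows that the lower number of compound 2 does not follow from every replacement at this position, but belongs to 4-(tert-butyl)phenyl among the three groups shown. Nothing in the available data explains why these groups differ or match.

On these data alone, the ring nitrogen and the trifluoromethyl group enter together, so their separate contributions stay open, and a compound with 4-(trifluoromethyl)phenyl on the carbonyl carbon would pull them apart. Also open, as far as these compounds go, is how an aliphatic amine or a carboxylic acid on this aryl ring would read in this assay when set beside these three compounds.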